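Furan-2-yl in place of 1H-pyrrol-2-yl: working notes on the series

The compounds below may be only part of what the source reports. "The series", "measured", "known", "first", "only" and "open" are said of these compounds alone.

The series is read in a functional assay on CCRF-CEM cells (Homo sapiens) for cytotoxicity, with a stated time of 72 h; a higher number here means a weaker inhibitor, a lower number a stronger inhibitor. For the measured compounds named here, compound 1 `CCOC(=O)/C=C/C=C/C=C/C=C/c1ccc[nH]1` gives 1340 nM, the only actual number available so far. Compound 2 `CCOC(=O)/C=C/C=C/c1ccco1` reports only a limit, > 10000 nM. Compound 3 `CCOC(=O)/C=C/C=C/C=C/c1ccco1` also reports only a limit, > 10000 nM.

Going by the values given here, compounds 2 and 3 both carry furan-2-yl on a shorter chain than compound 1, so ring and chain length differ together, and no measured pair separates the two changes. Compound 4 `CCOC(=O)/C=C/C=C/C=C/C=C/c1ccco1` keeps the chain of compound 1 and changes the ring: furan-2-yl in place of 1H-pyrrol-2-yl on a double-bonded chain carbon bound to a double-bonded chain carbon. The change is furan-2-yl in place of 1H-pyrrol-2-yl on a double-bonded chain carbon bound to a double-bonded chain carbon.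

Among the compounds with values here, with no measured step for this change, the size of the move remains an expectation. Compound 1 at 1340 nM is the anchor for the longer chain. Compound 3, the nearest furan-2-yl relative, stays a limit at > 10000 nM, which pulls the expectation towards weaker values. A moderate weakening is expected, estimated as a 2.1-fold higher number from compound 1 to compound 4 (0.32 log units; beyond the scatter), and a result at the limit of the assay remains possible. For compound 4 the estimate is 2800 nM, with an expected range of 800 nM to 10000 nM.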

Compound 4, half-maximal inhibitory concentration: > 10000 nM
Compound 4 ended at the assay's limit; the forecaster's own chance of this, stated with the estimate: 25%; at least 3.5-fold (0.55 log units) between middle value and limit.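

For the compounds shown here, with the chain of compound 1 held constant, this is the first measured pair that separates the ring from chain length: furan-2-yl in place of 1H-pyrrol-2-yl on a double-bonded chain carbon bound to a double-bonded chain carbon gives an at least 7.4-fold higher number from compound 1 to compound 4 (0.87 log units; beyond the scatter) in this assay. Compound 4 gives > 10000 nM, which is a limit of the assay and not a number. The longer chain alone therefore does not keep a measurable value, 1H-pyrrol-2-yl is the only ring with one among the compounds shown, and the step sets only a floor on the size of the change: the limit of > 10000 nM in this assay, at which 3 of the 4 values shown sit.

Steps among compounds 2, 3 and 4 cannot be read, all three being limits, so the effect of chain length on the furan-2-yl compounds stays unknown. Also open, as far as these compounds go, is whether the loss tracks the ring hydrogen-bond donor, which a 1-methylpyrrol-2-yl or thiophen-2-yl ring on the same chain would test, and how 1H-pyrrol-2-yl behaves on a shorter or longer chain.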